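Flipping One Stereocentre in Compound 2

This account rests on a few compounds, and the source may have more. Where it says the series, first, only, none or still open, it means among the compounds named here.

In a functional assay on HuTu80 cells (Homo sapiens) for antiproliferative activity, read by MTT assay, with a stated time of 72 h (a higher number here means a weaker inhibitor, a lower number a stronger inhibitor), compound 1 (`COc1ccc([C@@H]2[C@H](O)C(=O)N2c2cc(OC)c(OC)c(OC)c2)cc1O`) gives 28.8 nM, while compound 2 (`COc1ccc(N2C(=O)[C@@H](O)[C@H]2c2cc(OC)c(OC)c(OC)c2)cc1O`) gives 2550 nM. That is the higher of the two numbers, beyond the usual scatter, so compound 2 is the weaker inhibitor of this pair.

Compound 3 (`COc1ccc(N2C(=O)[C@@H](O)[C@@H]2c2cc(OC)c(OC)c(OC)c2)cc1O`) has the same atoms and bonds as compound 2 and differs only in configuration as drawn (the two compounds have the same atoms and bonds and differ only in configuration as drawn: 1 of 2 stereo elements differ; a stereocentre at a saturated ring carbon is drawn R in compound 2 and S in compound 3): a stereocentre at a saturated ring carbon is drawn R in compound 2 and S in compound 3.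

Among the compounds with values here, no measured pair here shows what such a change does in this assay, so any expectation is loose and either direction stays open. The expected result is a 1.4-fold lower number from compound 2 to compound 3 (0.15 log units; within the scatter), a small move towards a lower number that would stay within the scatter. Compound 3 is estimated at 1800 nM, with an expected range of 250 nM to 10000 nM.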

Compound 3, half-maximal inhibitory concentration: 406 nM
The estimate for compound 3 lay 4.4-fold (0.65 log units) above the measured number; the measured number falls inside the stated range.
By their numbers in this assay, from the lowest: compound 1; then compound 3; then compound 2.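

This stereocentre at a saturated ring carbon matters: in this assay, drawing it S rather than R gives a 6.3-fold lower number from compound 2 to compound 3 (0.80 log units; beyond the scatter). The earlier compounds shown here could not show this, since compound 1 and compound 2 differ in more than one place. This step isolates a single stereocentre, and the change can be assigned to configuration alone because no atom or bond changes: the fact that compounds 2 and 3 differ only in the configuration as drawn

Going by these compounds, what stays open is why this configuration gives the lower number, since these compounds hold no measurement that could explain it, and whether the same step would appear with the other stereo element reversed. On these data alone, it is also open how an amine or a longer chain on the shared core would behave with either configuration at this stereocentre.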